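This account rests on a few compounds, and the source may have more. Where it says the series, first, only, none or still open, it means among the compounds named here.

Measured compounds:
- compound 1, `CC1(C)OC(C)(C)c2c1nnc(-c1ccccc1)[n+]2[O-]`, 163 mg/kg
- compound 2, `CC1(C)OC(C)(C)c2c1nnc(-c1cccc([N+](=O)[O-])c1)[n+]2[O-]`, 72 mg/kg
- compound 3, `CC1(C)OC(C)(C)c2c1nnc(-c1cc([N+](=O)[O-])cc([N+](=O)[O-])c1)[n+]2[O-]`, 500 mg/kg

In a functional assay on the whole organism with Mus musculus as the target (a higher number here means that more compound is needed for the effect, a lower number that less compound is needed), compound 1 gives 163 mg/kg, which places it second highest of the three numbers: compound 2 sits lower, compound 3 higher. The unmeasured compound 4, `CC1(C)OC(C)(C)c2c1nnc(-c1ccc(F)cc1)[n+]2[O-]`, differs from compound 1 by fluoro in place of hydrogen on an aromatic carbon; read one bond further out, phenyl becomes 4-fluorophenyl.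

Among the compounds with values here, two measured steps bear on substitution of this ring. The first, a 2.3-fold lower number from compound 1 to compound 2 (0.35 log units; beyond the scatter), shows that a single added group on the ring can lower the number modestly; the second, a 6.9-fold higher number from compound 2 to compound 3 (0.84 log units; beyond the scatter), shows that a further group can raise it again. Neither step involves fluoro, and neither places a group para to a large group, so they bear only loosely on compound 4. The expected step is therefore small: a 1.3-fold lower number from compound 1 to compound 4 (0.10 log units; within the scatter), most likely within the scatter, with a slight lean toward a lower number. Compound 4 is estimated at 130 mg/kg, within a range of 60 mg/kg to 330 mg/kg.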

Compound 4, dose for half-maximal effect: 500 mg/kg
Beside the measured number, compound 4's estimate is 3.8-fold (0.59 log units) below it, and the stated range ends below it.
By their numbers in this assay, from the lowest: compound 2; then compound 1; then compounds 3 and 4 (each within the scatter of the next).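

In this assay, adding a single fluoro para to a large group on the aromatic ring is not a neutral change: it gives a 3.1-fold higher number from compound 1 to compound 4 (0.49 log units; beyond the scatter). Within the data shown here, one added heavy atom at this position is thus enough to raise the number beyond the scatter, whereas the single nitro of the earlier compounds went the other way, with a 2.3-fold lower number from compound 1 to compound 2 (0.35 log units; beyond the scatter), and a rise had appeared only with a second nitro. Nothing among the data shown offers an explanation for this rise.

The compounds shown do not settle whether the rise belongs to fluoro itself or to this position on the ring. Going by these compounds, whether chloro, a methoxy group, an amine or a carboxylic acid in the same place would also raise the number remains open.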